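Swapping a pyridinyloxy for a pyrrolidinylsulfonyl: cytotoxicity outlook

This account rests on a few compounds, and the source may have more. Where it says the series, first, only, none or still open, it means among the compounds named here.

Measured so far:
compound 1, `O=C(Nc1cccc(Oc2ccccn2)c1)C1CCCN(C(=O)c2cc(C(F)(F)F)cc(C(F)(F)F)c2)C1`, 0%
compound 2, `O=C(Nc1ccc(Cl)cc1)C1CCCN(C(=O)c2cccc(-c3cccs3)c2)C1`, 4%

In an ADME assay on PC-3 cells (Homo sapiens) for cytotoxicity, read by WST assay, tested at 100 uM (on this read-out higher numbers stand for more inhibition at the one concentration tested (going by the name of the read-out) and lower numbers for less inhibition), compound 1 gives 0%. Compound 2 gives 4% in this assay; the two numbers lie within the usual scatter of each other, so neither can be called more or less toxic than the other. Both sit at the bottom of the scale, meaning essentially no growth inhibition at the single concentration tested.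

Compound 3, `O=C(Nc1cccc(S(=O)(=O)N2CCCC2)c1)C1CCCN(C(=O)c2cc(C(F)(F)F)cc(C(F)(F)F)c2)C1`, has not yet been measured. It differs from compound 1 in one place: (pyrrolidin-1-yl)sulfonyl in place of (pyridin-2-yl)oxy on an aromatic carbon. Going by the values given here, no measured pair shows what this kind of change does in this assay, so there is no observed step to lean on. With both measured compounds near zero, the expectation is a step that stays within the scatter. The estimated step is a number 3 percentage points higher from compound 1 to compound 3 (within the scatter), leading to an expected value for compound 3 of 3%, in a range from 0% to 15%.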

Compound 3, a percentage reported as inhibition, at one concentration (the size of the read-out at that concentration, not a potency): 0%
Compound 3: the middle estimate sits 3 percentage points above what was measured; the range from low to high includes it.
By their numbers in this assay, from the lowest: compounds 1, 3 and 2 (each within the scatter of the next).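

In this assay, going by these compounds alone, the exchange of (pyridin-2-yl)oxy for (pyrrolidin-1-yl)sulfonyl on this aromatic carbon gives no change at the digits printed from compound 1 to compound 3 (within the scatter) and so provides the first direct reading of a single change. At this place, meta to a large group, a sulfonyl group carrying a non-aromatic ring can stand in for an oxygen-linked aromatic ring without moving the read-out, at the one concentration tested. No measurement shown here explains why the read-out stays the same.

From the compounds shown here alone, whether a different kind of group at this place, such as a primary amine or a carboxylic acid, would move the read-out remains open. So does whether the same exchange would leave the read-out unmoved on the core of compound 2.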